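The source may hold more compounds than are shown below. What is called first, only, known or untested is meant among the compounds shown, and "the series" means these compounds.

Measured compounds:
- compound 1, `COc1ccc(/C=C/c2cc(OC)cc(OC)c2/C=C/C(=O)c2cccc(OC)c2)cc1`, 6.1 ug/mL
- compound 2, `CCCCOc1ccc(C(=O)/C=C/c2c(/C=C/c3ccc(OC)cc3)cc(OC)cc2OC)cc1`, 8.7 ug/mL
- compound 3, `COc1ccc(/C=C/c2cc(OC)cc(OC)c2/C=C/C(=O)c2ccc(Br)cc2)cc1`, 8.3 ug/mL

These three compounds share one core and differ only in the ring attached to the carbonyl carbon. In a functional assay on A549 cells (Homo sapiens) for antiproliferative activity, read by MTT assay, with a stated time of 48 h (a higher number here means a weaker inhibitor, a lower number a stronger inhibitor), compound 2 gives the highest of the three numbers, but its nearest neighbour compound 3 sits only a 1.0-fold lower number from compound 2 to compound 3 (0.02 log units; within the scatter) away, and compound 1, the furthest, differs by a 1.4-fold higher number from compound 1 to compound 2 (0.15 log units; within the scatter); neither gap exceeds the scatter, so the three cannot be ranked.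

Compound 4, `COc1ccc(/C=C/c2cc(OC)cc(OC)c2/C=C/C(=O)c2ccc(C)cc2C)cc1`, has not yet been measured. Compared with compound 2 it carries 2,4-dimethylphenyl in place of 4-butoxyphenyl on a carbonyl carbon.

Within the data shown here, two measured steps bear on this change, since each also swaps the ring on the carbonyl carbon: a 1.4-fold higher number from compound 1 to compound 2 (0.15 log units; within the scatter) and a 1.4-fold higher number from compound 1 to compound 3 (0.13 log units; within the scatter). Both lie within the scatter, as does a 1.0-fold lower number from compound 2 to compound 3 (0.02 log units; within the scatter). Three different groups on the carbonyl carbon thus gave numbers that are indistinguishable in this assay. On that basis no step beyond the scatter is expected for compound 4 in either direction.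

Compound 4 is therefore estimated at 7.5 ug/mL, with a range from 3.5 ug/mL to 16 ug/mL, which amounts to an expected step of a 1.2-fold lower number from compound 2 to compound 4 (0.06 log units; within the scatter).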

Compound 4, half-maximal inhibitory concentration: 0.3 ug/mL
Estimate against measurement, compound 4: 25-fold (1.40 log units) above, and the stated range ends above it.
By their numbers in this assay, from the lowest: compound 4; then compounds 1, 3 and 2 (each within the scatter of the next).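

In this assay, the ring on the carbonyl carbon turns out to matter a great deal: bringing in 2,4-dimethylphenyl gives a 29-fold lower number from compound 2 to compound 4 (1.46 log units; beyond the scatter), a 28-fold lower number from compound 3 to compound 4 (1.44 log units; beyond the scatter) and a 20-fold lower number from compound 1 to compound 4 (1.31 log units; beyond the scatter). Each of these steps lies beyond the scatter, so compound 4 is the strongest inhibitor of the four, while 3-methoxyphenyl, 4-butoxyphenyl and 4-bromophenyl remain indistinguishable from one another, and the flat picture they gave holds only for those three rings. No measurement is available that explains why this ring stands apart from the others.

The compounds shown do not separate the two methyl groups, so it stays open whether 2-methylphenyl or 4-methylphenyl alone would give a number as low as that of compound 4, or whether both groups are needed. From the compounds shown here alone, what a ring carrying an amine or a carboxylic acid would give at this position is also open, and all four numbers come from this assay alone, so whether the large steps would appear in other cells cannot be told.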